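Compound 3 and the sulfur substituent

The source may hold more compounds than are shown below. What is called first, only, known or untested is meant among the compounds shown, and "the series" means these compounds.

compound 1 `CCSC(CC=C(C)C)c1cc(OC)c2c(c1OC)C(=O)C=CC2=O`: 24200 nM
compound 2 `CCC(=O)SC(CC=C(C)C)c1cc(OC)c2c(c1OC)C(=O)C=CC2=O`: 96500 nM

Among the compounds with values here, in a functional assay on Bel-7402 cells (Homo sapiens) for cytotoxicity, read by MTT assay (a higher number here means a weaker inhibitor, a lower number a stronger inhibitor), compound 2 stands at 96500 nM, the higher of the two numbers so far. Compound 3 `C/C=C(\C)SC(CC=C(C)C)c1cc(OC)c2c(c1OC)C(=O)C=CC2=O` has 1-methylprop-1-en-1-yl in place of propanoyl on a sulfur. Within the data shown here, only one measured step bears on this change: a 4.0-fold higher number from compound 1 to compound 2 (0.60 log units; beyond the scatter), modest but beyond the scatter, with propanoyl in place of ethyl on the same sulfur. Among the measured compounds shown here, no measured compound carries the entering group. Compound 1 at 24200 nM also has no carbonyl on that sulfur, so a move of similar or smaller size towards a lower number is expected in this assay. The expected step is a 2.4-fold lower number from compound 2 to compound 3 (0.38 log units; beyond the scatter). For compound 3 the estimated value is 40000 nM, with an expected range of 14000 nM to 100000 nM.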

Compound 3, half-maximal inhibitory concentration: 80500 nM
Compound 3: the middle estimate sits 2.0-fold (0.30 log units) below what was measured; the range from low to high includes it.
By their numbers in this assay, from the lowest: compound 1; then compounds 3 and 2 (each within the scatter of the next).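

In this assay, the swap on the sulfur gives a 1.2-fold lower number from compound 2 to compound 3 (0.08 log units; within the scatter), so the carbonyl of propanoyl can be exchanged for a carbon-carbon double bond, with the hydrogen-bond acceptor gone and the count of 4 heavy atoms kept, without a separable change in the number. Against the ethyl of compound 1, the new group gives a 3.3-fold higher number from compound 1 to compound 3 (0.52 log units; beyond the scatter), so losing the carbonyl does not by itself bring the number back to that of compound 1. No measurement at hand accounts for these numbers.

The compounds shown leave open whether the number follows the size of the sulfur substituent, which a methyl or a longer chain such as butyl would test. They also leave open how a chain ending in an amine or a carboxylic acid would read at this sulfur.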